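Aminoglycoside ethers with a second undecyl chain: cytotoxicity notes

The source may hold more compounds than are shown below. What is called first, only, known or untested is meant among the compounds shown, and "the series" means these compounds.

Measured so far:
compound 1 `CCCCCCCCCCCO[C@@H]1[C@@H](O)[C@H](O[C@H]2O[C@H](CN)[C@@H](O)[C@H](O)[C@H]2N)[C@@H](N)C[C@H]1N` gives 74.7%
compound 2 `CCCCCCCCCCCO[C@@H]1[C@@H](N)[C@@H](O[C@H]2[C@H](O)[C@@H](O)[C@H](N)C[C@@H]2N)O[C@H](CN)[C@H]1O` gives 81.8%
compound 3 `CCCCCCCO[C@@H]1[C@@H](N)[C@@H](O[C@H]2[C@H](O)[C@@H](O)[C@H](N)C[C@@H]2N)O[C@H](CN)[C@H]1O` gives 77.5%

In an ADME assay on J774 cells (Mus musculus) for cytotoxicity, read by MTT assay, with a stated time of 24 h, tested at 10 uM (on this read-out lower numbers stand for a stronger effect and higher numbers for a weaker effect at the one concentration tested), the three measured compounds sit close together. Compound 2 lies within the scatter of both others: a number 4.3 percentage points lower from compound 2 to compound 3 (within the scatter), and the number for compound 1 sits within the scatter of that for compound 2 as well.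

Compound 4 `CCCCCCCCCCCO[C@@H]1[C@@H](N)[C@@H](O[C@H]2[C@H](O)[C@@H](OCCCCCCCCCCC)[C@H](N)C[C@@H]2N)O[C@H](CN)[C@H]1O` differs from compound 2 by undecyl in place of hydrogen on an oxygen on a saturated carbon. Within the data shown here, no measured step bears on this change; the one measured step, from compound 2 to compound 3, concerns chain length, and it fell within the scatter. The expected size of step is therefore uncertain, and a downward step, a number 16.8 percentage points lower from compound 2 to compound 4 (beyond the scatter), is only a guess. Compound 4 is estimated at 65%, expected between 40% and 85%.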

Compound 4, a percentage reported as activity, at one concentration (the size of the read-out at that concentration, not a potency): 81.7%
For compound 4 the middle estimate is 16.7 percentage points below the measured one, within the range that was stated.
By their numbers in this assay, from the lowest: compounds 1, 3, 4 and 2 (each within the scatter of the next).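

In this assay, undecyl in place of hydrogen on an oxygen on a saturated carbon reads as a number 0.1 percentage points lower from compound 2 to compound 4 (within the scatter), and the comparison with the other undecyl ether reads as a number 7 percentage points higher from compound 1 to compound 4 (within the scatter). Hydroxy to undecyloxy at this position thus gives no step beyond the scatter, which the earlier chain-length step could not show. No evidence is available to explain this result.

Still open, from the compounds shown here alone, is whether a shorter chain, an amine or a carboxylic acid on this oxygen would also stay within the scatter. A single concentration also leaves open how these compounds compare at higher doses.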